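A few compounds are considered here, and "the series" means these few. Any claim that something is new, unique, unknown or untested is made for them only; others in the source may bear on it.

Of the compounds shown here, three that share one core have been tested in an ADME assay on HepG2 2.2.15 cells (Homo sapiens) for cytotoxicity, with a stated time of 9 days; on this read-out higher numbers stand for lower toxicity in this test and lower numbers for higher toxicity in this test. Compound 1 `Cc1ccc(SCc2nc3c(Cn4ccnc4)c(O)ccc3n2C)cc1` gives 60800 nM in this assay. Compound 2 `COc1ccc(SCc2nc3c(Cn4ccnc4)c(O)ccc3n2C)cc1` gives 64500 nM. Compound 3 `COc1ccc(SCc2nc3c(Cn4ccnc4C)c(O)ccc3n2C)cc1` gives 164000 nM, the highest of the three numbers.

Two single changes connect these compounds. The first is methyl in place of methoxy on an aromatic carbon, which produced a 1.1-fold lower number from compound 2 to compound 1 (0.03 log units; within the scatter). The second is methyl in place of hydrogen on an aromatic carbon, which produced a 2.5-fold higher number from compound 2 to compound 3 (0.41 log units; beyond the scatter); this is also how the core of compound 3 differs from the core of compound 2.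

Compound 4 `Cc1ccc(SCc2nc3c(Cn4ccnc4C)c(O)ccc3n2C)cc1` has not yet been measured in this assay. It differs from compound 3 by methyl in place of methoxy on an aromatic carbon. Going by the values given here, this is the same change as the one between compound 2 and compound 1, made at the same place, only now on the core of compound 3 rather than the core of compound 2. Among the compounds with values here, the one earlier example of this change is therefore the main guide to what compound 4 will show, together with the position of compound 3 at the top of the measured range.

On that basis the expected step from compound 3 to compound 4 in this assay is a 1.1-fold lower number from compound 3 to compound 4 (0.04 log units; within the scatter), which rests on a 1.1-fold lower number from compound 2 to compound 1 (0.03 log units; within the scatter). Compound 4 is accordingly estimated at 150000 nM, with a likely range from 70000 nM to 320000 nM.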

Compound 4, half-maximal cytotoxic concentration: 91200 nM
For compound 4 the middle estimate is 1.6-fold (0.22 log units) above the measured one; low and high end bracket the measured number.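

Putting methyl in place of methoxy on the 4-methoxyphenyl group gives a similar result on both cores in this assay, where the new example is a 1.8-fold lower number from compound 3 to compound 4 (0.25 log units; within the scatter), and the two examples agree: the same change on two cores in this assay, a 1.1-fold lower number (0.03 log units; within the scatter) from compound 2 to compound 1 and a 1.8-fold lower number (0.25 log units; within the scatter) from compound 3 to compound 4, 1.7-fold (0.23 log units) apart, within the scatter of two such steps.

Putting methyl in place of hydrogen on an aromatic carbon, the other change in this set, gives a 1.5-fold higher number from compound 1 to compound 4 (0.18 log units; within the scatter), so this example stays within the scatter while the earlier one lies beyond it, yet the two do not differ by more than the scatter of two such steps: the same change on two cores in this assay, a 2.5-fold higher number (0.41 log units; beyond the scatter) from compound 2 to compound 3 and a 1.5-fold higher number (0.18 log units; within the scatter) from compound 1 to compound 4, 1.7-fold (0.23 log units) apart, within the scatter of two such steps.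

This shows that each change behaved compatibly across these two cores, but it does not show that the steps are identical, and two examples per change cannot establish a rule for other cores in the series.

The compounds shown hold only methoxy or methyl on the phenyl ring and only hydrogen or methyl at the other changed place, so the effect of a chlorine, a trifluoromethyl or a carboxylic acid at the first place, or a longer chain at the second, remains open. Also open, from the compounds shown here alone, is whether these modest differences in cell toxicity would persist beyond these four compounds.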